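Oxime series: halogen swap from compound 2 to compound 3

The source may hold more compounds than are shown below. What is called first, only, known or untested is meant among the compounds shown, and "the series" means these compounds.

Measured compounds:
- compound 1 `COc1ccc(C(/C=C/c2ccc(F)cc2)=N/O)cc1`: in an ADME assay on cells (Mus musculus, strain Balb/c) for cytotoxicity, read by MTT assay, with a stated time of 48 h (on this read-out lower numbers stand for higher toxicity in this test and higher numbers for lower toxicity in this test), compound 1 gives 13500 nM
- compound 2 `O/N=C(\C=C\c1ccc(Cl)cc1)c1ccc(Cl)cc1`: in this assay compound 2 gives 14100 nM

Of the two numbers, that of compound 2 is nominally the higher, but compound 1 sits within the usual scatter of it, so no difference between the two can be claimed. Among the compounds with values here, the two measured compounds differ from each other in more than one place, so no single-point step between them is available, and nothing in the set isolates the effect of a halogen swap.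

Compound 3 `O/N=C(\C=C\c1ccc(F)cc1)c1ccc(Cl)cc1` has not yet been run in this assay. Relative to compound 2 the change is fluoro in place of chloro on an aromatic carbon. Both measured compounds carry a halogen at that position and give nearly identical numbers, so the expectation is a step of essentially zero, well within the scatter; the expected step is a 1.0-fold lower number from compound 2 to compound 3 (0.01 log units; within the scatter). For compound 3 the estimated value in this assay is 13800 nM, with a range from 7000 nM to 27000 nM.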

Compound 3, half-maximal cytotoxic concentration: 11500 nM
Beside the measured number, compound 3's estimate is 1.2-fold (0.08 log units) above it; measured number inside the range.
By their numbers in this assay, from the lowest: compounds 3, 1 and 2 (each within the scatter of the next).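

In this assay, the series now has its first single-point readings: fluoro in place of chloro on an aromatic carbon, para to a large group, gives a 1.2-fold lower number from compound 2 to compound 3 (0.09 log units; within the scatter) and so cannot be told apart from the scatter at this position. Chloro in place of methoxy on an aromatic carbon gives a 1.2-fold lower number from compound 1 to compound 3 (0.07 log units; within the scatter) and is likewise not distinguishable, so neither of the two single-point changes moves the read-out measurably, and the earlier pair, which differed in more than one place, could not show this for either change taken alone. Nothing measured on these compounds offers a reason for either reading.

Open, from the compounds shown here alone, is whether this position stays as flat with a group of a different kind, such as an amine, a carboxylic acid or a longer alkyl chain, as all three compounds carry only a halogen or methoxy on their aromatic carbons. Also open, going by these compounds, is whether the read-out depends on the oxime hydroxyl, which a methyl ether of the oxime would test against the shared core.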